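Trifluoromethyl in Place of Fluoro on the Benzyl Ring

This account rests on a few compounds, and the source may have more. Where it says the series, first, only, none or still open, it means among the compounds named here.

Compound 1, `C=CCOc1ccc2c(=O)c(-c3cc(OC)c(OC)cc3OC)coc2c1`, gives 6600 nM in a functional assay on HCT-116 cells (Homo sapiens) for antiproliferative activity, read by MTT assay, with a stated time of 24 h; a lower number here means a stronger inhibitor, a higher number a weaker inhibitor.
Compound 2, `COc1ccc2c(=O)c(-c3cc(OC)c(OC)cc3OC)coc2c1`, gives 9170 nM in this assay.
Compound 3, `COc1cc(OC)c(-c2coc3cc(OCc4ccccc4F)ccc3c2=O)cc1OC`, gives 2900 nM in this assay.

Compound 3 stands at the lowest number of the three. The step of a 2.3-fold lower number from compound 1 to compound 3 (0.36 log units; beyond the scatter) and the step of a 3.2-fold lower number from compound 2 to compound 3 (0.50 log units; beyond the scatter) both lie beyond the scatter, while the step of a 1.4-fold higher number from compound 1 to compound 2 (0.14 log units; within the scatter) does not, so swapping vinyl for hydrogen on the saturated chain carbon bound to the ring oxygen changed little, whereas placing the 2-fluorophenyl there gave a modest gain.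

Compound 4, `COc1cc(OC)c(-c2coc3cc(OCc4ccccc4C(F)(F)F)ccc3c2=O)cc1OC`, differs from compound 3 only by trifluoromethyl in place of fluoro on an aromatic carbon. Among the measured compounds shown here, none of the measured steps bears directly on this change: each of them alters what sits on the saturated chain carbon bound to an oxygen on an aromatic ring, and none alters a group on the 2-fluorophenyl itself. There is therefore no measured ground for expecting a step beyond the scatter in this assay in either direction.

Compound 4 is estimated to give 2600 nM, in a range from 1000 nM to 7000 nM, which amounts to an expected step of a 1.1-fold lower number from compound 3 to compound 4 (0.05 log units; within the scatter).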

Compound 4, half-maximal inhibitory concentration: 4760 nM
The estimate for compound 4 lay 1.8-fold (0.26 log units) below the measured number; the range from low to high includes it.
By their numbers in this assay, from the lowest: compounds 3, 4, 1 and 2 (each within the scatter of the next, the first and the last beyond it).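

In this assay, trifluoromethyl brings four heavy atoms where fluoro has one, yet the change on this aromatic carbon stays small, a 1.6-fold higher number from compound 3 to compound 4 (0.22 log units; within the scatter), so the larger group is accommodated here without a step beyond the scatter. The new group does, however, blur a distinction: compound 3 stood beyond the scatter from both simpler ethers, whereas a 1.9-fold lower number from compound 2 to compound 4 (0.28 log units; within the scatter) and a 1.4-fold lower number from compound 1 to compound 4 (0.14 log units; within the scatter) both remain within it. No measurement is available that would explain this result.

The compounds shown leave open how an amine, a carboxylic acid or a nitrile on this aromatic carbon would read in this assay. They also leave open whether the same exchange of fluoro for trifluoromethyl would give a similar result at another carbon of this ring.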